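The compounds below may be only part of what the source reports. "The series", "measured", "known", "first", "only" and "open" are said of these compounds alone.

Of the compounds shown here, three sharing one core have been tested in a functional assay on MCF7 cells (Homo sapiens) for cytotoxicity, read by CellTiter-Glo, with a stated time of 5 days; a lower number here means a stronger inhibitor, a higher number a weaker inhibitor. There, compound 1 `CC/C(=C(/c1ccc(/C=C/C(=O)O)cc1)c1ccc2[nH]c(=O)oc2c1)c1ccccc1` gives 56 nM, compound 3 `CC/C(=C(/c1ccc(/C=C/C(=O)O)cc1)c1ccc2cn[nH]c2c1)c1ccccc1` gives 570 nM, and compound 2 `CC/C(=C(/c1ccc(/C=C/C(=O)O)cc1)c1ccc2[nH]ncc2c1)c1ccccc1` gives 6 nM, the lowest number of the three. Compound 4 `CC/C(=C(/c1ccc(/C=C/C(=O)O)cc1)c1ccc2[nH]ncc2c1)c1ccccc1Cl` differs from compound 2 in one place: chloro in place of hydrogen on an aromatic carbon. In words, this is chloro in place of hydrogen on an aromatic carbon, turning phenyl into 2-chlorophenyl.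

For the measured compounds named here, no measured step touches that phenyl ring, so the evidence is only indirect. The three known steps all change a different group: a 9.3-fold lower number from compound 1 to compound 2 (0.97 log units; beyond the scatter), a 10-fold higher number from compound 1 to compound 3 (1.01 log units; beyond the scatter) and a 95-fold higher number from compound 2 to compound 3 (1.98 log units; beyond the scatter). The last of these only exchanges 1H-indazol-5-yl for 1H-indazol-6-yl, so a small edit can matter greatly among these compounds. None of the steps indicates a direction for adding chloro. The expectation is therefore no step beyond the scatter, held with a wide margin on both sides. The expected step is a 1.2-fold lower number from compound 2 to compound 4 (0.08 log units; within the scatter). Compound 4 is estimated at 5 nM, with an expected range from 1.2 nM to 25 nM.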

Compound 4, half-maximal inhibitory concentration: 2 nM
Compound 4: the middle estimate sits 2.5-fold (0.40 log units) above what was measured; low and high end bracket the measured number.
By their numbers in this assay, from the lowest: compound 4; then compound 2; then compound 1; then compound 3.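

The phenyl ring, which no earlier step touched, is not a silent part of these compounds: 2-chlorophenyl in place of phenyl gives a 3.0-fold lower number from compound 2 to compound 4 (0.48 log units; beyond the scatter) in this assay and this step lies beyond the scatter. A single chlorine atom, on an aromatic carbon ortho to a large group, can thus still lower the number of a compound that already had the lowest number of the first three. Nothing measured here explains why this step occurs.

As far as these compounds go, whether fluoro, methyl or methoxy in the same place would give a similar step remains open. So does whether the 2-chlorophenyl group would lower the number to the same extent in compound 1 or compound 3, whose other ring groups differ.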